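Swapping the aryl ketone in a trimethoxyphenyl triazolothiadiazine series

This account rests on a few compounds, and the source may have more. Where it says the series, first, only, none or still open, it means among the compounds named here.

Measured compounds:
- compound 1, `COc1cc(-c2nnc3n2NC(c2ccco2)C(C(=O)c2ccc(F)c(F)c2)S3)cc(OC)c1OC`, 93700 nM
- compound 2, `COc1cc(-c2nnc3n2NC(c2cccs2)C(C(=O)c2ccc(Cl)cc2)S3)cc(OC)c1OC`, 20100 nM
- compound 3, `COc1cc(-c2nnc3n2NC(c2ccco2)C(C(=O)c2ccccc2C)S3)cc(OC)c1OC`, 80000 nM

In a functional assay on A549 cells (Homo sapiens) for cytotoxicity, read by MTT assay, with a stated time of 48 h (a higher number here means a weaker inhibitor, a lower number a stronger inhibitor), compound 1 gives the highest number of the three measured compounds. Compound 3 sits closest to it, and the step of a 1.2-fold lower number from compound 1 to compound 3 (0.07 log units; within the scatter) lies within the scatter. Compound 2 is furthest away; no single-point step links it to compound 1, so its value can only be set beside that of compound 1 as shown above.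

Compound 4 is `COc1cc(-c2nnc3n2NC(c2ccco2)C(C(=O)c2ccc(Cl)cc2)S3)cc(OC)c1OC`. It differs from compound 1 in one place: 4-chlorophenyl in place of 3,4-difluorophenyl on a carbonyl carbon. Within the data shown here, the only measured step at that carbonyl position, a 1.2-fold lower number from compound 1 to compound 3 (0.07 log units; within the scatter), was within the scatter, which argues against a large change. Compound 2, however, carries the same 4-chlorophenyl on its carbonyl carbon and gives a clearly lower number than compound 1, though it also differs elsewhere. Weighing both, a moderate decrease is expected for compound 4 in this assay, described by the step of a 2.7-fold lower number from compound 1 to compound 4 (0.43 log units; beyond the scatter). Compound 4 is therefore estimated at 35000 nM, with a range from 12000 nM to 100000 nM.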

Compound 4, half-maximal inhibitory concentration: 51400 nM
Compound 4: the middle estimate sits 1.5-fold (0.17 log units) below what was measured; the measured number falls inside the stated range.
By their numbers in this assay, from the lowest: compound 2; then compounds 4, 3 and 1 (each within the scatter of the next).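

At the carbonyl carbon, three aryl groups can now be compared with furan-2-yl held constant in this assay. The steps of a 1.8-fold lower number from compound 1 to compound 4 (0.26 log units; within the scatter) and a 1.6-fold lower number from compound 3 to compound 4 (0.19 log units; within the scatter) both lie within the scatter, so 3,4-difluorophenyl, 2-methylphenyl and 4-chlorophenyl cannot be told apart there. With 4-chlorophenyl held constant, the change on the saturated ring carbon can also be read on its own: a 2.6-fold higher number from compound 2 to compound 4 (0.41 log units; beyond the scatter), a modest step beyond the scatter, so the lower number of compound 2 goes with thiophen-2-yl rather than with its aryl ketone; nothing available explains this difference.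

Going by these compounds, it remains open whether thiophen-2-yl gives the same step with 3,4-difluorophenyl or 2-methylphenyl on the carbonyl carbon. On these data alone, it is equally open whether an aryl group bearing an amine or a carboxylic acid would move the number beyond the scatter.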